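The compounds below may be only part of what the source reports. "The series", "measured", "known", "first", "only" and "open" are said of these compounds alone.

Two compounds of this series carry numbers in a functional assay on A498 cells (Homo sapiens) for inhibition, read by sulforhodamine B assay, with a stated time of 48 h; a lower number here means a stronger inhibitor of growth, a higher number a weaker inhibitor of growth. Compound 1 `COc1cc(C(=O)N2CCN(C=O)C2=S)cc(OC)c1OC` gives 20500 nM, and compound 2 `O=CN1CCN(c2ccc(Cl)cc2)C1=S` gives 14800 nM, the lower of the two, though its gap to compound 1 lies within the scatter. Compound 3 `O=CN1CCN(c2ccc(Cl)c(Cl)c2)C1=S` is not yet measured; it differs from compound 2 by chloro in place of hydrogen on an aromatic carbon. For the measured compounds named here, no step between measured compounds is available to set the size of such a change, so only a small effect is expected, not beyond the scatter and if anything toward a lower number, a 1.5-fold lower number from compound 2 to compound 3 (0.17 log units; within the scatter). Compound 3 is therefore expected to give 10000 nM, with a range from 4000 nM to 30000 nM.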

Compound 3, concentration for 50% growth inhibition: 15800 nM
Beside the measured number, compound 3's estimate is 1.6-fold (0.20 log units) below it, within the range that was stated.
By their numbers in this assay, from the lowest: compounds 2, 3 and 1 (each within the scatter of the next).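

Chloro in place of hydrogen on an aromatic carbon, ortho to a chloro group and meta to a group of 8 heavy atoms, gives the first reading of this change in this assay: a 1.1-fold higher number from compound 2 to compound 3 (0.03 log units; within the scatter). At this position, the two compounds cannot be told apart, and this single pair sets no trend for the series. No evidence on hand bears on this result. On these data alone, whether an amine or a carboxylic acid at this position would give a number beyond the scatter remains open. So does the reading for chloro on the other carbons of this ring.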